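Phenyl for hydrogen on the sulfonamide ring of compound 3

A few compounds are considered here, and "the series" means these few. Any claim that something is new, unique, unknown or untested is made for them only; others in the source may bear on it.

In an assay on Sf9 cells for inhibition of mitogen-activated protein kinase kinase kinase 20 (Homo sapiens), read by ADP-Glo, with a stated time of 30 min (on this read-out higher numbers stand for weaker inhibition and lower numbers for stronger inhibition), compound 3 `COc1n[nH]c2ncc(-c3cn(-c4c(F)ccc(NS(=O)(=O)c5ccccc5)c4F)nn3)cc12` gives 3.8 nM. That is the lowest of the three numbers in this series. The next closest is compound 2 `COc1n[nH]c2ncc(-c3cn(-c4cccc(NS(=O)(=O)c5cccc(Cl)c5)c4)nn3)cc12`, which in this assay gives 24.7 nM, and the furthest is compound 1 `COc1n[nH]c2ncc(-c3nnc(-c4c(F)ccc(NS(=O)(=O)c5cccc(Cl)c5)c4F)o3)cc12`, which gives 63.3 nM; both gaps lie beyond the usual scatter, so compound 3 is the strongest inhibitor of the three measured compounds. The unmeasured compound 4 `COc1n[nH]c2ncc(-c3cn(-c4c(F)ccc(NS(=O)(=O)c5cccc(-c6ccccc6)c5)c4F)nn3)cc12` keeps the whole framework of compound 3 and differs in one place only: phenyl in place of hydrogen on an aromatic carbon. Among the measured compounds shown here, no pair of measured compounds shows this change, so no step for it is known, and the two compounds carrying a substituent on that ring, compound 1 and compound 2, differ from compound 3 elsewhere as well, so their values cannot be read as a step. With a group of this size entering where only a hydrogen stood, the expected result is a modest weakening, wide in uncertainty, in this assay: compound 4 is expected to show a step of a 3.2-fold higher number from compound 3 to compound 4 (0.50 log units; beyond the scatter). Compound 4 is therefore estimated to give 12 nM in this assay, within a range from 2.5 nM to 60 nM.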

Compound 4, half-maximal inhibitory concentration: 4 nM
Compound 4: middle estimate off by 3.0-fold (0.48 log units), on the high side; measured number inside the range.
By their numbers in this assay, from the lowest: compounds 3 and 4 (each within the scatter of the next); then compound 2; then compound 1.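

In this assay, phenyl in place of hydrogen on this aromatic carbon, meta to a large group, gives a 1.1-fold higher number from compound 3 to compound 4 (0.02 log units; within the scatter), so the two compounds cannot be told apart on this read-out. Among the compounds shown here, this is the first direct reading at this position, since compound 1 and compound 2 differ from compound 3 elsewhere as well, and it shows that a whole phenyl ring can stand here while the number stays level with that of compound 3. Nothing measured on these compounds says why the number holds when the ring enters.

A single step with a single group leaves open whether this place accepts other kinds of group in the same way, such as an amine, a carboxylic acid or a longer alkyl chain, or whether a methoxy group or a chlorine on the new phenyl ring would shift the number. From the compounds shown here alone, it is equally open whether the same change would read the same on the frameworks of compound 1 and compound 2, which carry chlorine on that ring and differ from compound 3 elsewhere.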